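The compounds below may be only part of what the source reports. "The series", "measured", "known", "first", "only" and "open" are said of these compounds alone.

Compound 1 `CCn1c(N)c(-c2nc3ccccc3[nH]2)c2nc(C#N)c(C#N)nc21` in a functional assay on HL-60 cells (Homo sapiens) for antiproliferative activity, read by MTT assay, with a stated time of 48 h (on this read-out lower numbers stand for stronger inhibition and higher numbers for weaker inhibition), gives > 50000 nM, which is a limit of the assay rather than a number. Compound 2 `CCCn1c(N)c(-c2nc3ccccc3[nH]2)c2nc(C#N)c(C#N)nc21` gives 45200 nM. Compound 3 `N#Cc1nc2c(-c3nc4ccccc4[nH]3)c(N)n(CCCN3CCCCC3)c2nc1C#N` gives 1680 nM.

Compound 2 holds the highest of the two numbers shown; its nearest neighbour is compound 3, reached by a 27-fold lower number from compound 2 to compound 3 (1.43 log units; beyond the scatter). Compound 4 `CN(C)CCCCCn1c(N)c(-c2nc3ccccc3[nH]2)c2nc(C#N)c(C#N)nc21` differs from compound 2 in 2-(dimethylamino)ethyl in place of hydrogen on a saturated chain carbon, three bonds along the chain from an aromatic nitrogen. The step that bears on this is a 27-fold lower number from compound 2 to compound 3 (1.43 log units; beyond the scatter), where piperidin-1-yl enters at the same place; an at least 29-fold lower number from compound 1 to compound 3 (1.47 log units; beyond the scatter) points the same way. A second amine-bearing chain of this kind is therefore expected to give a large step in the lower direction, an 18-fold lower number from compound 2 to compound 4 (1.26 log units; beyond the scatter). Compound 4 is estimated at 2500 nM, with a range from 800 nM to 8000 nM.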

Compound 4, half-maximal inhibitory concentration: 3420 nM
Compound 4: the middle estimate sits 1.4-fold (0.14 log units) below what was measured; the range from low to high includes it.
By their numbers in this assay, from the lowest: compound 3; then compound 4; then compound 2. At a limit, above all of these: compound 1.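

In this assay, the gain at this place is not confined to piperidin-1-yl: a 2-(dimethylamino)ethyl group, with no ring, also gives a 13-fold lower number from compound 2 to compound 4 (1.12 log units; beyond the scatter), while exchanging one amine for the other gives only a 2.0-fold higher number from compound 3 to compound 4 (0.31 log units; beyond the scatter). The comparison with the shorter chain, an at least 14-fold lower number from compound 1 to compound 4 (1.16 log units; beyond the scatter), is only a floor. Compound 1 stands at a limit, not a number: the limit of > 50000 nM in this assay, at which 1 of the 4 values shown sits.

Still open, from the compounds shown here alone, is whether the chain's amine nitrogen is itself required, which a chain ending in a hydroxyl or a carboxylic acid would test. Going by these compounds, whether a morpholine ring would serve like piperidin-1-yl also remains open.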